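Replacing the 2-methylpiperidin-1-yl group with a larger amine

A few compounds are considered here, and "the series" means these few. Any claim that something is new, unique, unknown or untested is made for them only; others in the source may bear on it.

Working notes on a small set built on one shared core. Compound 2 is `CC(C(=O)NCc1ccc(C(F)(F)F)nc1N1CCCCC1C)c1ccc(NS(C)(=O)=O)c(F)c1`; compound 3 is `CC(C(=O)NCc1ccc(C(F)(F)F)nc1N1CCC2(CC1)CC(C(C)(C)C)=NO2)c1ccc(NS(C)(=O)=O)c(F)c1`; compound 1 is `CC(C(=O)NCc1ccc(C(F)(F)F)nc1NCC1CCN(C(=O)OC(C)(C)C)CC1)c1ccc(NS(C)(=O)=O)c(F)c1`. In a functional assay on CHO-K1 cells for antagonist activity at transient receptor potential cation channel subfamily V member 1 (Homo sapiens), read by FLIPR (on this read-out higher numbers stand for weaker inhibition and lower numbers for stronger inhibition), compound 2 gives 2.9 nM. In this assay compound 3 gives 3.8 nM, and this number and that of compound 2 lie within the usual scatter of each other, so no order can be read between them. In this assay compound 1 gives 19.3 nM, a number that stands beyond the scatter from compound 2. Of the three measured numbers, compound 2 carries the lowest, with compound 3 nearest and compound 1 furthest.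

Compound 4 is `CC(C(=O)NCc1ccc(C(F)(F)F)nc1N1CCN(C2CCCCC2)CC1)c1ccc(NS(C)(=O)=O)c(F)c1`. It differs from compound 2 in one place: 4-cyclohexylpiperazin-1-yl in place of 2-methylpiperidin-1-yl on an aromatic carbon. For the measured compounds named here, no pair of measured compounds shows this same change, so the size of its step is not known from the data. The group that enters is large, and a large group at the same place is tolerated in compound 3, which gives 3.8 nM; a different large group in compound 1 gives 19.3 nM. On this basis the step of a 2.1-fold higher number from compound 2 to compound 4 (0.32 log units; beyond the scatter) is expected to be small, toward a higher number, and not clearly beyond the scatter. For compound 4 the estimate in this assay is 6 nM, with a range from 1.5 nM to 25 nM.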

Compound 4, inhibition constant: 21.6 nM
The estimate for compound 4 lay 3.6-fold (0.56 log units) below the measured number; low and high end bracket the measured number.
By their numbers in this assay, from the lowest: compounds 2 and 3 (each within the scatter of the next); then compounds 1 and 4 (each within the scatter of the next).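

In this assay, the change from 2-methylpiperidin-1-yl to 4-cyclohexylpiperazin-1-yl on this aromatic carbon next to the ring nitrogen gives a 7.4-fold higher number from compound 2 to compound 4 (0.87 log units; beyond the scatter), the first step measured at this place, and it shows that the change is not neutral here. A larger amine is therefore not accommodated equally in every case: compound 3, which also carries a large group at this place, gives 3.8 nM and stands with compound 2 in the lower pair, while compound 4 stands with compound 1 in the higher pair, so the larger size of the entering group does not by itself set the number. Nothing in the available data bears on the cause of this step.

For the compounds shown here, the change adds a cyclohexyl group and a second ring nitrogen together, and the single step cannot assign its size to either one. A 4-cyclohexylpiperidin-1-yl group at this place would keep the cyclohexyl without the second ring nitrogen, and a 4-methylpiperazin-1-yl group would keep that nitrogen without the cyclohexyl, so the pair would separate the two contributions.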